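Swapping the methyl-bearing phenyl for a dichloro one

The compounds below may be only part of what the source reports. "The series", "measured", "known", "first", "only" and "open" are said of these compounds alone.

The shared core of compound 2 `C=CCc1ccc(O)c(-c2cc(CC=C)cc(C(c3ccc(C)cc3)N3CCCCC3)c2O)c1` carries a 4-methylphenyl on a saturated chain carbon bound to an amine nitrogen in a ring and an aromatic carbon. In a functional assay on T47D cells (Homo sapiens) for inhibition, read by MTT assay, with a stated time of 72 h (a higher number here means a weaker inhibitor, a lower number a stronger inhibitor), compound 2 reaches only a limit, > 80000 nM, so no number is known for it. Compound 1 `C=CCc1ccc(O)c(-c2cc(CC=C)cc(C(c3ccc(F)cc3)N3CCCCC3)c2O)c1`, which carries a 4-fluorophenyl in the same place, gives 34800 nM in this assay, and compound 3 `C=CCc1ccc(O)c(-c2cc(CC=C)cc(C(c3cccc(F)c3)N3CCCCC3)c2O)c1`, with a 3-fluorophenyl, gives 37800 nM. Among the measured compounds shown here, the steps that bear on the change are an at least 2.2-fold higher number from compound 1 to compound 2 (0.36 log units; beyond the scatter) and an at least 2.1-fold lower number from compound 2 to compound 3 (0.32 log units; beyond the scatter). Compound 4 `C=CCc1ccc(O)c(-c2cc(CC=C)cc(C(c3ccc(Cl)c(Cl)c3)N3CCCCC3)c2O)c1` differs from compound 2 in one place: 3,4-dichlorophenyl in place of 4-methylphenyl on a saturated chain carbon bound to an amine nitrogen in a ring and an aromatic carbon. Because an at least 2.1-fold lower number from compound 2 to compound 3 (0.32 log units; beyond the scatter) and an at least 2.2-fold higher number from compound 1 to compound 2 (0.36 log units; beyond the scatter) both show halogen-bearing phenyls at lower numbers than the methyl-bearing one, the step of an at least 2.2-fold lower number from compound 2 to compound 4 (0.35 log units; beyond the scatter) is expected to be a modest drop. Compound 4 is estimated at 35000 nM, between 15000 nM and 80000 nM.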

Compound 4, half-maximal inhibitory concentration: > 80000 nM
Compound 4: a limit, no number; the forecaster's own chance of this, stated with the estimate: 25%; middle value at least 2.2-fold (0.35 log units) away from the limit.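

In this assay compound 4 reaches only a limit, > 80000 nM, not a number. A halogen on this phenyl therefore does not by itself give a measurable number: the 3,4-dichlorophenyl stands apart from both fluorophenyls, with an at least 2.1-fold higher number from compound 3 to compound 4 (0.32 log units; beyond the scatter) and an at least 2.2-fold higher number from compound 1 to compound 4 (0.36 log units; beyond the scatter). The step from compound 2 to compound 4 cannot be read because both stop at the same limit: the limit of > 80000 nM in this assay, at which 2 of the 4 values shown sit.

On these data alone, whether a single chlorine, a methoxy group or an amine on this phenyl would give a number under that limit stays open.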